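Swapping phenyl for benzyl in compound 3

A few compounds are considered here, and "the series" means these few. Any claim that something is new, unique, unknown or untested is made for them only; others in the source may bear on it.

Of the compounds shown here, three sharing one core have been tested in a functional assay on HCT-116 cells (Homo sapiens) for antiproliferative activity, read by resazurin assay, with a stated time of 5 days; a higher number here means a weaker inhibitor, a lower number a stronger inhibitor. Compound 1 `O=C(CCCC1CCN(S(=O)(=O)Cc2ccccc2)CC1)NO`, which carries a benzyl group, gives 3200 nM. Compound 2 `O=C(CCCC1CCN(C(=O)c2ccccc2)CC1)NO` gives 17200 nM. Compound 3 `O=C(CCCC1CCN(C(=O)Nc2ccccc2)CC1)NO` gives 700 nM, the lowest of the three numbers, and its gaps to both others lie beyond the scatter.

Compound 4 `O=C(CCCC1CCN(C(=O)NCc2ccccc2)CC1)NO` differs from it by one change: benzyl in place of phenyl on an amide-type nitrogen. In words, this is benzyl in place of phenyl on an amide-type nitrogen. Among the compounds with values here, only one measured step bears on this part of the molecule, the large 25-fold lower number from compound 2 to compound 3 (1.39 log units; beyond the scatter), which put anilino in place of phenyl on a carbonyl carbon. Within the data shown here, that step shows the number can move far here, but no measured step makes this exact swap. Among the measured compounds shown here, compound 1, the only tested compound with benzyl, stands at a higher number than compound 3, so a modest weakening is expected. The expected step is a 2.1-fold higher number from compound 3 to compound 4 (0.33 log units; beyond the scatter). For compound 4 the estimated value is 1500 nM, with an expected range of 400 nM to 6000 nM.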

Compound 4, half-maximal inhibitory concentration: 300 nM
Estimate against measurement, compound 4: 5.0-fold (0.70 log units) above, and the stated range ends above it.
By their numbers in this assay, from the lowest: compound 4; then compound 3; then compound 1; then compound 2.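

In this assay, the change to benzyl on the amide-type nitrogen gives a 2.3-fold lower number from compound 3 to compound 4 (0.37 log units; beyond the scatter). Within the data shown here, the earlier compounds showed only that the number can move far in this part of the molecule; this step shows that a group with one more carbon than phenyl is tolerated on this nitrogen and, in this pair, goes with a modestly stronger result rather than a loss. Nothing measured here explains why the number falls with this swap.

The pair cannot show whether the number would keep falling with a longer chain on the same nitrogen, such as phenylethyl. Going by these compounds, how a methoxy group or a fluorine atom on the aromatic ring of compound 4 would shift the number also remains open.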